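A Dichlorophenyl Change Among Limit Values

The source may hold more compounds than are shown below. What is called first, only, known or untested is meant among the compounds shown, and "the series" means these compounds.

In a functional assay on U-937 cells (Homo sapiens) for antiproliferative activity, read by MTT assay, with a stated time of 24 h (on this read-out higher numbers stand for weaker inhibition of growth and lower numbers for stronger inhibition of growth), compound 3 (`Cc1cc(NC(=O)Nc2ccccc2F)ccc1NC(=O)c1cnoc1C`) gives only a limit, > 30000 nM. Compound 2 (`Cc1cc(NC(=O)Nc2cccc(Cl)c2)ccc1NC(=O)c1cnoc1C`) also gives only a limit, > 30000 nM. Compound 1 (`Cc1ccc(NC(=O)C(c2ccc(Cl)cc2)c2ccc(Cl)cc2)cc1NC(=O)c1cnoc1C`) likewise gives a limit, > 30000 nM. Going by the values given here, the series so far therefore shows (the limit of > 30000 nM in this assay, at which 3 of the 3 values shown sit), and compound 3 has no numerical position. Compound 4 (`Cc1cc(NC(=O)Nc2ccc(Cl)c(Cl)c2)ccc1NC(=O)c1cnoc1C`) carries 3,4-dichlorophenyl in place of 2-fluorophenyl on an amide-type nitrogen. Among the compounds with values here, the one measured step that bears on this change is a step that the two limits leave unreadable from compound 2 to compound 3, which offers neither size nor direction to carry over. In this assay, the expected step is a number no higher from compound 3 to compound 4 (the limit leaves the size open), with no reliable shift beyond the scatter. For compound 4, the estimated value is 30000 nM, with an expected range of 10000 nM to 60000 nM.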

Compound 4, concentration for 50% growth inhibition: > 30000 nM
Compound 4: no number, only a limit; the forecaster's own chance of this, stated with the estimate: 70%; the middle value lies on the limit itself.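

Going by these compounds alone, compound 4 gives only a limit, > 30000 nM, and no step to it from compound 2 or compound 3 can be read. The compounds shown leave open what values lie behind these limits and whether either change shifts growth inhibition at all.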